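Moving a halogen change from one benzyl ring to another

A few compounds are considered here, and "the series" means these few. Any claim that something is new, unique, unknown or untested is made for them only; others in the source may bear on it.

Compound 1 `CN(Cc1ccccc1F)C(=O)c1cc2c(Cc3ccccc3)n[nH]c2cc1O` carries a fluoro group on one of its benzyl rings, and in a functional assay on A2780 cells (Homo sapiens) for antiproliferative activity, read by resazurin assay, with a stated time of 72 h (on this read-out higher numbers stand for weaker inhibition and lower numbers for stronger inhibition), compound 1 gives 1500 nM. Compound 2 `CN(Cc1ccccc1Cl)C(=O)c1cc2c(Cc3ccccc3)n[nH]c2cc1O` differs from it in a single way: chloro in place of fluoro on an aromatic carbon. In this assay compound 2 gives 1100 nM, so that a 1.4-fold lower number from compound 1 to compound 2 (0.13 log units; within the scatter). Compound 3 `CN(Cc1ccccc1)C(=O)c1cc2c(Cc3cccc(F)c3)n[nH]c2cc1O` has the same atoms as compound 1, joined differently; the difference between the two cores is not broken down here. In this assay compound 3 gives 1700 nM, a number that sits with the other two within the usual spread of repeated measurements.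

Compound 4 `CN(Cc1ccccc1)C(=O)c1cc2c(Cc3cccc(Cl)c3)n[nH]c2cc1O` has not yet been measured. It differs from compound 3 by the same kind of change that took compound 1 to compound 2: chloro in place of fluoro on an aromatic carbon. The surroundings are not identical, though: in compound 2 the entering chloro group sits ortho to a large group, whereas in compound 4 it sits meta to a large group. Within the data shown here, the one measured example of this kind of change, a 1.4-fold lower number from compound 1 to compound 2 (0.13 log units; within the scatter), stayed within the scatter. On that basis a step of similar size is expected for compound 4, a 1.3-fold lower number from compound 3 to compound 4 (0.12 log units; within the scatter). This rests on a single measured pair, and the different surroundings add uncertainty. Compound 4 is therefore estimated at 1300 nM, with the result expected to fall between 700 nM and 2600 nM.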

Compound 4, half-maximal inhibitory concentration: 410 nM
The estimate for compound 4 lay 3.2-fold (0.50 log units) above the measured number; measured number below the stated range.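

In this assay, chloro in place of fluoro on an aromatic carbon gives a 4.1-fold lower number from compound 3 to compound 4 (0.62 log units; beyond the scatter), so in this pair the swap of one halogen for another comes with a clear change in the read-out. Set beside the earlier pair, the same swap does not carry over at the same size from one core to the other: the same change on two cores in this assay, a 1.4-fold lower number (0.13 log units; within the scatter) from compound 1 to compound 2 and a 4.1-fold lower number (0.62 log units; beyond the scatter) from compound 3 to compound 4, 3.0-fold (0.48 log units) apart, beyond the scatter of two such steps What this does not show is why the two steps differ, or any general rule for chloro over fluoro, since there are only two pairs, and they differ both in which benzyl ring holds the halogen and in where it sits on that ring, with nothing here to separate those two differences.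

The compounds shown leave open how a bromo, a methoxy or a nitrile would behave in place of the chloro of the 3-chlorobenzyl group, and how the same compound would read with plain hydrogen at that spot. They also leave open whether a chloro on each of the two benzyl rings in one molecule would give a step like either of those seen for a single swap.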